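The source may hold more compounds than are shown below. What is called first, only, known or untested is meant among the compounds shown, and "the series" means these compounds.

In a functional assay on PC-3 cells (Homo sapiens) for cytotoxicity, read by MTT assay, with a stated time of 48 h (on this read-out lower numbers stand for stronger inhibition and higher numbers for weaker inhibition), compound 1 `CC1=NN(C(=O)CN2CCCCC2)C(c2ccccc2O)C1` gives 5890 nM. Compound 2 `CC1=NN(C(=O)CN2CCCC2)C(c2ccccc2O)C1` gives 6670 nM, and a 1.1-fold higher number from compound 1 to compound 2 (0.05 log units; within the scatter). Compound 3 `CC1=NN(C(=O)CN2CCC(c3ccccc3)CC2)C(c2ccccc2O)C1` gives 20400 nM, the highest number of the three measured compounds and thus the weakest inhibitor here, with both gaps beyond the scatter. Compound 4 `CC1=NN(C(=O)CN2CCC(Cl)CC2)C(c2ccccc2O)C1` differs from compound 3 in one place: chloro in place of phenyl on a saturated ring carbon. Within the data shown here, one measured step bears on this change, the one that brought the phenyl in: a 3.5-fold higher number from compound 1 to compound 3 (0.54 log units; beyond the scatter). Removing that phenyl and leaving a single chlorine in its place is expected to undo much of that rise, so compound 4 is expected to show a 2.6-fold lower number from compound 3 to compound 4 (0.41 log units; beyond the scatter). The estimated value for compound 4 is therefore 8000 nM, within a range from 3500 nM to 18000 nM.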

Compound 4, half-maximal inhibitory concentration: 34800 nM
For compound 4 the middle estimate is 4.4-fold (0.64 log units) below the measured one, outside the stated range (above it).
By their numbers in this assay, from the lowest: compounds 1 and 2 (each within the scatter of the next); then compounds 3 and 4 (each within the scatter of the next).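

At this saturated ring carbon, one chlorine atom and a whole phenyl ring cannot be told apart (a 1.7-fold higher number from compound 3 to compound 4 (0.23 log units; within the scatter)), so the rise seen with phenyl does not need six heavy atoms. Chloro in place of hydrogen already gives a rise beyond the scatter (a 5.9-fold higher number from compound 1 to compound 4 (0.77 log units; beyond the scatter)), and the swap of pyrrolidin-1-yl for 4-chloropiperidin-1-yl gives a similar one (a 5.2-fold higher number from compound 2 to compound 4 (0.72 log units; beyond the scatter)). Nothing measured here explains why. Going by these compounds, whether any group at this position keeps the number as low as hydrogen remains open. A methyl group or an amine there would help to answer that.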